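Methyl on the phenyl group, tested across two cores

The source may hold more compounds than are shown below. What is called first, only, known or untested is meant among the compounds shown, and "the series" means these compounds.

Working notes on a small set of thiophene anilides and their heterocyclic relatives. In a functional assay on Hs 683 cells (Homo sapiens) for inhibition, read by colorimetric assay and MTT assay, with a stated time of 72 h (a higher number here means a weaker inhibitor, a lower number a stronger inhibitor), compound 1 `COc1cc(OC)cc(C(=O)NNC(=S)Nc2csc(-c3ccccc3)c2)c1` gives 42000 nM. Compound 2 `COc1cc(OC)cc(C(=O)NNC(=S)Nc2csc(-c3ccc(C)cc3)c2)c1` differs from it by methyl in place of hydrogen on an aromatic carbon and gives 37000 nM in this assay, so the step of a 1.1-fold lower number from compound 1 to compound 2 (0.06 log units; within the scatter) changes nothing that the assay can resolve.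

Compound 3 `Oc1ccc(-c2nnc(Nc3csc(-c4ccccc4)c3)s2)cc1` is built on a different core; the difference between the two cores is not broken down here. In this assay compound 3 gives 26000 nM. Its number lies within the usual scatter of the numbers of compound 1 and compound 2, so no order among the three can be stated.

Compound 4 `Cc1ccc(-c2cc(Nc3nnc(-c4ccc(O)cc4)s3)cs2)cc1` has not been measured. It differs from compound 3 by methyl in place of hydrogen on an aromatic carbon, which is the same change at the same place as that from compound 1 to compound 2. Because a 1.1-fold lower number from compound 1 to compound 2 (0.06 log units; within the scatter) stayed within the scatter, the corresponding step is expected to do the same, and the estimated change from compound 3 to compound 4 is a 1.1-fold lower number from compound 3 to compound 4 (0.03 log units; within the scatter). Among the compounds with values here, for compound 4 the expected value in this assay is therefore 24000 nM, with a likely range from 12000 nM to 50000 nM, resting on the one earlier instance of this change and on the single number for compound 3.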

Compound 4, half-maximal inhibitory concentration: 17000 nM
Estimate against measurement, compound 4: 1.4-fold (0.15 log units) above, and the stated range covers the measured number.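

In this assay, the phenyl to 4-methylphenyl change on the second core gives a 1.5-fold lower number from compound 3 to compound 4 (0.18 log units; within the scatter), so on neither core does this change produce a difference that the assay can resolve. Set side by side, the two instances cannot be told apart: the same change on two cores in this assay, a 1.1-fold lower number (0.06 log units; within the scatter) from compound 1 to compound 2 and a 1.5-fold lower number (0.18 log units; within the scatter) from compound 3 to compound 4, 1.3-fold (0.13 log units) apart, within the scatter of two such steps

This supports carrying the change between these two cores only in a limited sense, as a step that stays within the scatter on both, and it does not show a real methyl effect shared by the cores, nor anything about a third core, as it rests on two steps built from single numbers.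

The compounds shown hold only hydrogen or methyl at this place on the phenyl ring, so it remains open whether an amine, a carboxylic acid or a longer chain there would move the number beyond the scatter, and whether such a step would then carry from one core to the other. The separate contribution of each core also remains open, as no pair shown differs in the core alone.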